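From Pyrazole to Thiazole: Estimating Compound 4

The compounds below may be only part of what the source reports. "The series", "measured", "known", "first", "only" and "open" are said of these compounds alone.

Of the compounds shown here, three have been measured in an assay on HEK293F cells for inhibition of cholesterol 24-hydroxylase (Homo sapiens), read by trypan blue exclusion, with stated times of 15 min and 5 h; on this read-out lower numbers stand for stronger inhibition and higher numbers for weaker inhibition. Compound 1 `CNC(=O)C1CCN(c2cncnc2-c2ccccc2)CC1` gives 72 nM in this assay. Compound 2 `Cc1cnn(-c2ccncc2N2CCC(C(=O)N(C)C)CC2)c1` gives 8.5 nM, and compound 3 `Cc1ccn(-c2ccncc2N2CCC(C(=O)N(C)C)CC2)n1` gives 1100 nM. Compound 3 therefore stands highest of the three numbers, with compound 1 nearest and compound 2 furthest from it. Among the compounds with values here, the one step that touches compound 3 is a 130-fold higher number from compound 2 to compound 3 (2.11 log units; beyond the scatter), which shows that changing the group at this position moves the number a long way.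

Compound 4 `Cc1cnc(-c2ccncc2N2CCC(C(=O)N(C)C)CC2)s1` has not yet been measured. The change is 5-methyl-1,3-thiazol-2-yl in place of 3-methyl-1H-pyrazol-1-yl on an aromatic carbon. Within the data shown here, no measured pair shows a five-membered ring with sulfur entering at this place, so the step from the pyrazole to the thiazole has no direct precedent; the only relevant evidence is the large step from compound 2 to compound 3, which says the position is sensitive, and the value of compound 1, which carries a carbon-linked aromatic group at the corresponding place and gives a middling number. On that basis the step is expected to be a 9.2-fold lower number from compound 3 to compound 4 (0.96 log units; beyond the scatter), toward a lower number but with wide uncertainty. Compound 4 is thus estimated at 120 nM, within a range from 20 nM to 700 nM.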

Compound 4, half-maximal inhibitory concentration: 12 nM
Beside the measured number, compound 4's estimate is 10-fold (1.00 log units) above it, outside the stated range (below it).
By their numbers in this assay, from the lowest: compounds 2 and 4 (each within the scatter of the next); then compound 1; then compound 3.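

The large step, a 92-fold lower number from compound 3 to compound 4 (1.96 log units; beyond the scatter) in this assay, shows that the high number of compound 3 does not extend to every five-membered aromatic ring with 2 hetero atoms at this place, since 5-methyl-1,3-thiazol-2-yl brings the number back into the range of the better pyrazole. Against that pyrazole, the change gives a 1.4-fold higher number from compound 2 to compound 4 (0.15 log units; within the scatter), so 5-methyl-1,3-thiazol-2-yl and 4-methyl-1H-pyrazol-1-yl cannot be told apart on this read-out, although they differ in their ring atoms; among the three compounds that differ only in this group, compound 3 alone stands apart. Nothing available here accounts for why this one pyrazole stands so far from the other two rings.

From the compounds shown here alone, the earlier step, a 130-fold higher number from compound 2 to compound 3 (2.11 log units; beyond the scatter), showed that moving the methyl around the pyrazole matters greatly, and whether moving it around the thiazole matters as much remains open, as does whether the thiazole needs a methyl group at all. Going by these compounds, it is also open what an ethyl group, a longer chain or an amine would do in place of that methyl on either ring.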